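Swapping the halogenated phenyl on compound 2's pyrazole nitrogen

The compounds below may be only part of what the source reports. "The series", "measured", "known", "first", "only" and "open" are said of these compounds alone.

Measured compounds:
- compound 1, `COc1ccc(-c2nc(-c3ccccc3)c(-c3ccc4c(c3)NC(=O)CO4)[nH]2)cc1`: 19.1%
- compound 2, `O=C1COc2ccc(-c3nn(-c4ccc(Br)cc4)cc3-c3ccccc3)cc2N1`: 54.2%
- compound 3, `O=C1COc2ccc(-c3[nH]c(-c4c[nH]c5ncccc45)nc3-c3ccccc3)cc2N1`: 53.5%

In a functional assay on DLD-1 cells (Homo sapiens) for cytotoxicity, read by colorimetric assay and MTT assay, with a stated time of 3 days, tested at 20 uM (a higher number here means a weaker effect of the compound at the concentration tested, a lower number a stronger effect), compound 2 stands highest of the three; compound 3 lies within the scatter of it, while compound 1 lies well below. Among the compounds with values here, the one step with a counted difference, a number 34.4 percentage points higher from compound 1 to compound 3 (beyond the scatter), concerns the other side of the shared core and does not bear on the change at hand.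

Compound 4, `O=C1COc2ccc(-c3nn(-c4cc(Cl)cc(Cl)c4)cc3-c3ccccc3)cc2N1`, differs from compound 2 by 3,5-dichlorophenyl in place of 4-bromophenyl on an aromatic nitrogen. Within the data shown here, no measured step touches this position, so no direction can be drawn from the data. Compound 4 is therefore expected to sit near compound 2, with an estimated step of a number 2.2 percentage points lower from compound 2 to compound 4 (within the scatter), giving an estimate of 52% (range 28% to 76%).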

Compound 4, a percentage reported as activity, at one concentration (the size of the read-out at that concentration, not a potency): 52.2%
For compound 4 the middle estimate is 0.2 percentage points below the measured one; the measured number falls inside the stated range.
By their numbers in this assay, from the lowest: compound 1; then compounds 4, 3 and 2 (each within the scatter of the next).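

In this assay, replacing 4-bromophenyl with 3,5-dichlorophenyl on the aromatic nitrogen gives a number 2 percentage points lower from compound 2 to compound 4 (within the scatter) and so does not separate the two compounds. At this position, therefore, the exchange of one halogenated phenyl for another, both counted without hydrogen-bond donors or acceptors, leaves the read-out within the scatter. Nothing available explains this result.

From the compounds shown here alone, whether a phenyl carrying an amine or a carboxylic acid at this nitrogen would change the read-out remains open. So does whether a saturated group such as cyclohexyl would do so in place of the phenyl ring.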